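Replacing the Trifluoromethylphenyl Arm with a Thiophene

A few compounds are considered here, and "the series" means these few. Any claim that something is new, unique, unknown or untested is made for them only; others in the source may bear on it.

For the measured compounds named here, compound 2 `CN1C(=O)C(c2ccccc2C(F)(F)F)N(C)c2nc(Nc3ccc(S(N)(=O)=O)cc3)ncc21` gives 56 nM in an assay on Sf9 cells for inhibition of serine/threonine-protein kinase 4 (Homo sapiens), read by luminescence and ADP-Glo, with a stated time of 1 h, in the presence of a further agent that is not named here (on this read-out lower numbers stand for stronger inhibition and higher numbers for weaker inhibition), the lowest of the two numbers so far. Its nearest neighbour is compound 1 `CN1C(=O)C(c2cccc(C(F)(F)F)c2)N(C)c2nc(Nc3ccc(S(N)(=O)=O)cc3)ncc21`, which in this assay gives 2710 nM. Going by the values given here, the one measured step, a 48-fold lower number from compound 1 to compound 2 (1.68 log units; beyond the scatter), shows how much the read-out shifts when the trifluoromethyl group is moved to another position on the phenyl ring. Compound 3 `CN1C(=O)C(c2cccs2)N(C)c2nc(Nc3ccc(S(N)(=O)=O)cc3)ncc21` has not yet been measured; it carries thiophen-2-yl in place of 2-(trifluoromethyl)phenyl on a saturated ring carbon. Among the compounds with values here, no measured step covers this exchange directly. The step on record concerns only where the trifluoromethyl group sits on a phenyl ring that is given up entirely here, so it serves as an indirect guide at best. Given the size of a 48-fold lower number from compound 1 to compound 2 (1.68 log units; beyond the scatter), a large rise in the number is expected, though with wide uncertainty. Compound 3 is estimated at 600 nM, within 100 nM to 4000 nM, an expected step of an 11-fold higher number from compound 2 to compound 3 (1.03 log units; beyond the scatter).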

Compound 3, half-maximal inhibitory concentration: 88 nM
Compound 3: the middle estimate sits 6.8-fold (0.83 log units) above what was measured; measured number outside the range, below it.
By their numbers in this assay, from the lowest: compounds 2 and 3 (each within the scatter of the next); then compound 1.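

In this assay, the thiophen-2-yl group on the saturated ring carbon reads level with the 2-(trifluoromethyl)phenyl group (a 1.6-fold higher number from compound 2 to compound 3 (0.20 log units; within the scatter)), so among the compounds shown, a trifluoromethyl group and a six-membered aromatic ring are not needed at this position for a number in this range. For the compounds shown here, the same exchange made from the 3-(trifluoromethyl)phenyl group gives a large step (a 31-fold lower number from compound 1 to compound 3 (1.49 log units; beyond the scatter)), which leaves compound 1 as the one compound apart from the other two. No evidence is available on why the smaller five-membered aromatic ring matches the 2-(trifluoromethyl)phenyl group.

The compounds shown leave open whether this carbon needs an aromatic ring at all, or whether a cyclohexyl group or a plain methyl would read the same. Going by these compounds, it also remains open how thiophen-3-yl, or a phenyl ring carrying a chlorine or a methoxy group in place of the trifluoromethyl, would compare.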